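This account rests on a few compounds, and the source may have more. Where it says the series, first, only, none or still open, it means among the compounds named here.

Compound 3 `COc1cc(-c2ccnc(N)n2)cc2[nH]nc(N)c12` is one of three close relatives in which only the group on the aryl oxygen changes. In a physicochemical assay for solubility, read by LC-MS, in phosphate buffer, measured as kinetic solubility, with a stated time of 24 h, at 25 degrees C, at pH 7.4 (on this read-out lower numbers stand for lower solubility and higher numbers for higher solubility), compound 1 `CC(C)(C)Oc1cc(-c2ccnc(N)n2)cc2[nH]nc(N)c12` gives 68000 nM, while compound 2 `CC(C)Oc1cc(-c2ccnc(N)n2)cc2[nH]nc(N)c12` gives 354000 nM. For compound 3 this assay returns only a limit, > 100000 nM, so its place among the three is known just as a floor (the limit of > 100000 nM in this assay, at which 1 of the 3 values shown sits). Of the measured steps, a 5.2-fold higher number from compound 1 to compound 2 (0.72 log units; beyond the scatter), whereas an at least 1.4-fold higher number from compound 1 to compound 3 (0.16 log units; that floor lies within the scatter) and a step that the limit leaves unreadable from compound 2 to compound 3.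

Compound 4 `Nc1nccc(-c2cc(Oc3ccccc3)c3c(N)n[nH]c3c2)n1` continues from compound 3 by phenyl in place of methyl on an oxygen on an aromatic ring, that is, methoxy to phenoxy. The two steps that touch the same oxygen, from compound 1 to compound 3 and from compound 2 to compound 3, are the ones that bear on it, and neither yields a readable size, so the direction for this assay cannot be taken from them. With compound 3 standing at a limit, the estimate for compound 4 is 30000 nM, with a range from 5000 nM to 150000 nM, which would be a step of an at least 3.3-fold lower number from compound 3 to compound 4 (0.52 log units; beyond the scatter) and is offered only as an expectation.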

Compound 4, solubility: 117000 nM
Compound 4: middle estimate off by 3.9-fold (0.59 log units), on the low side, and the stated range covers the measured number.
By their numbers in this assay, from the lowest: compounds 1 and 4 (each within the scatter of the next); then compound 2.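

Phenyl on this oxygen brings the first aromatic ring into the series, and in this assay the result can be set against the two branched groups. Against isopropyl the change gives a 3.0-fold lower number from compound 2 to compound 4 (0.48 log units; beyond the scatter), while against tert-butyl it gives a 1.7-fold higher number from compound 1 to compound 4 (0.24 log units; within the scatter). Compound 4 thus sits within the scatter of compound 1 and apart from compound 2, so on this oxygen the ring does not carry the number past what tert-butyl gives.

From the compounds shown here alone, how compound 4 stands against compound 3 stays open, as the step between them cannot be read, compound 3 having only a limit: the limit of > 100000 nM in this assay, at which 1 of the 4 values shown sits. Also open is whether a cyclohexyl ring or a chain ending in an amine on this oxygen would read like phenyl or like isopropyl.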